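Diaryl urea series: amide tail and linker variation

The source may report more compounds than this note shows. Statements on the series, on what has been measured and on what is new or still open speak of the compounds shown alone.

Measured so far:
compound 1 `CNC(=O)CCc1ccc(NC(=O)Nc2ccc(Cl)c(C(F)(F)F)c2)cc1` gives 24000 nM
compound 2 `C/C(=C\C(=O)N1CC(C)OC(C)C1)c1ccc(NC(=O)Nc2ccc(Cl)c(C(F)(F)F)c2)cc1` reports only a limit, > 50000 nM
compound 3 `CNC(=O)/C=C(\C)c1ccc(NC(=O)Nc2ccc(Cl)c(C(F)(F)F)c2)cc1` reports only a limit, > 50000 nM

All three were run in a functional assay on KETR3 cells (Homo sapiens) for inhibition, read by MTT assay, with a stated time of 120 h; on this read-out higher numbers stand for weaker inhibition and lower numbers for stronger inhibition. Within the data shown here, compound 1 is the only one with a number, 24000 nM. For compound 3 the assay gives a limit and nothing more. For compound 2 likewise only a limit is known. Compound 1 and compound 3 differ in their cores: 2-(methylcarbamoyl)ethyl in place of 1-methyl-2-(methylcarbamoyl)ethenyl on an aromatic carbon. This step reads an at least 2.0-fold higher number from compound 1 to compound 3 (0.31 log units; beyond the scatter).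

Within the unsaturated core the amide is varied: 2,6-dimethylmorpholin-4-yl in place of methylamino on a carbonyl carbon. That step is a step that the two limits leave unreadable from compound 3 to compound 2, because of the limit of > 50000 nM in this assay, at which 2 of the 3 values shown sit.

Compound 4 `CC1CN(C(=O)CCc2ccc(NC(=O)Nc3ccc(Cl)c(C(F)(F)F)c3)cc2)CC(C)O1` is not yet measured. It carries the same kind of change on the saturated core: 2,6-dimethylmorpholin-4-yl in place of methylamino on a carbonyl carbon. The place is not identical: in compound 4 the carbonyl carbon's other neighbour is a saturated chain carbon, in compound 2 a double-bonded chain carbon.

As the measured pair gives no readable size, the expectation rests on the number of compound 1 alone, 24000 nM. For compound 4 a step of a 1.7-fold higher number from compound 1 to compound 4 (0.22 log units; within the scatter) is expected. Compound 4 is estimated at 40000 nM, between 15000 nM and 100000 nM.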

Compound 4, half-maximal inhibitory concentration: > 50000 nM
Compound 4: no number, only a limit; the forecaster's own chance of this, stated with the estimate: 45%; middle value at least 1.2-fold (0.09 log units) away from the limit.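

In this assay compound 4 reports only a limit, > 50000 nM. On the core of compound 1, 2,6-dimethylmorpholin-4-yl in place of methylamino on a carbonyl carbon gives an at least 2.0-fold higher number from compound 1 to compound 4 (0.31 log units; beyond the scatter), so this one pair shows that the change does not lower the number on that core. Whether the change carries over from one core to the other with a similar size stays unknown, because the step on the core of compound 3 cannot be read and the step on the core of compound 1 has no upper end: the limit of > 50000 nM in this assay, at which 3 of the 4 values shown sit.

Open, from the compounds shown here alone, is whether a smaller amine on the carbonyl carbon, such as dimethylamino or unsubstituted morpholine, gives a number rather than a limit on the core of compound 1. Also open, going by these compounds, is what a carboxylic acid in place of the amide, or a longer chain carrying the carbonyl, does to the number of that core.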